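A few compounds are considered here, and "the series" means these few. Any claim that something is new, unique, unknown or untested is made for them only; others in the source may bear on it.

Compound 1 `CC(C)c1cccc(OC(=O)c2cn(-c3ccccc3)nc2-c2cccnc2)c1` gives 11600 nM in a functional assay on Raji cells (Homo sapiens) for cytotoxicity, read by MTT assay, with a stated time of 48 h; on this read-out lower numbers stand for stronger inhibition and higher numbers for weaker inhibition; compound 2 `CC(C)(C)c1ccc(OC(=O)c2cn(-c3ccccc3)nc2-c2cccnc2)cc1` gives 42300 nM; compound 3 `O=C(Oc1ccc2ccccc2c1)c1cn(-c2ccccc2)nc1-c1cccnc1` gives "nd(insoluble)" (no result reported) and so stands without a number.

Going by the values given here, the one measured step, a 3.6-fold higher number from compound 1 to compound 2 (0.56 log units; beyond the scatter), concerns the aryl group on the oxygen next to the carbonyl and does not touch the pyridine, so nothing measured bears directly on the move from compound 3 to compound 4 `O=C(Oc1ccc2ccccc2c1)c1cn(-c2ccccc2)nc1-c1ccncc1`, in which (pyridin-4-yl in place of pyridin-3-yl on an aromatic carbon). Among the compounds with values here, with compound 3 unmeasured, the only anchors are compound 1 and compound 2, and a result for compound 4 in this assay may again be withheld. Compound 4 is expected to fall near 20000 nM, between 5000 nM and 80000 nM, should a number be obtained.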

Compound 4, half-maximal inhibitory concentration: 12100 nM
Compound 4: middle estimate off by 1.7-fold (0.22 log units), on the high side; the measured number falls inside the stated range.
By their numbers in this assay, from the lowest: compounds 1 and 4 (each within the scatter of the next); then compound 2.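

In this assay compound 3 has no number to set against compound 4 at 12100 nM and so no step can be read. The compounds shown leave open how pyridin-4-yl compares with pyridin-3-yl on the shared core. Nothing available bears on this result.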